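The compounds below may be only part of what the source reports. "The series", "measured", "known", "first", "only" and "open" are said of these compounds alone.

Of the compounds shown here, three sharing one core have been measured in an in vitro assay on Sf21 cells for inhibition of high affinity 3',5'-cyclic-AMP phosphodiesterase 7A (Homo sapiens), read by scintillation proximity assay, with a stated time of 30 min; a higher number here means a weaker inhibitor, a lower number a stronger inhibitor. Compound 1 `O=C(Nc1ccc(S(=O)(=O)Nc2nccs2)cc1)c1cn(Cc2c(F)cccc2F)c2ccc(=O)[nH]c2c1=O` gives 25 nM in this assay. Compound 2 `CC(=O)Nc1ccc(NC(=O)c2cn(Cc3c(F)cccc3Cl)c3ccc(=O)[nH]c3c2=O)cc1` gives 17 nM. Compound 3 `NS(=O)(=O)c1ccc(NC(=O)c2cn(Cc3c(F)cccc3Cl)c3ccc(=O)[nH]c3c2=O)cc1` gives 20 nM, a number that sits within the usual scatter of both of the others, so the three are not separable on these data. For the measured compounds named here, the one single-point step available, a 1.2-fold higher number from compound 2 to compound 3 (0.07 log units; within the scatter), changes a group on the same aromatic carbon that carries the sulfonamide and produces nothing beyond the scatter.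

Compound 4 `O=C(Nc1ccc(S(=O)(=O)Nc2nccs2)cc1)c1cn(Cc2c(F)cccc2Cl)c2ccc(=O)[nH]c2c1=O` differs from compound 3 by 1,3-thiazol-2-yl in place of hydrogen on a sulfonamide nitrogen. Going by the values given here, no measured pair isolates this exact change, but compound 1 already carries the (1,3-thiazol-2-yl)sulfamoyl group, combined with a different halogen pattern on the benzyl group, and its value in this assay lies within the scatter of compound 3. Taken with the flat step from compound 2 to compound 3 at the same part of the molecule, the expectation is a step of no more than the scatter, so that a 1.1-fold higher number from compound 3 to compound 4 (0.04 log units; within the scatter) is expected to be small in either direction. Compound 4 is therefore estimated to give 22 nM in this assay, with a range from 10 nM to 50 nM.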

Compound 4, half-maximal inhibitory concentration: 32 nM
Compound 4: the middle estimate sits 1.5-fold (0.16 log units) below what was measured; measured number inside the range.
By their numbers in this assay, from the lowest: compounds 2, 3, 1 and 4 (each within the scatter of the next).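

In this assay, putting 1,3-thiazol-2-yl in place of hydrogen on a sulfonamide nitrogen gives a 1.6-fold higher number from compound 3 to compound 4 (0.20 log units; within the scatter), and putting (1,3-thiazol-2-yl)sulfamoyl in place of acetamido on an aromatic carbon gives a 1.9-fold higher number from compound 2 to compound 4 (0.27 log units; within the scatter), so this first direct reading at that nitrogen, like the wider exchange on the aromatic carbon, stays within the scatter. For the compounds shown here, the new compound also gives the first reading of the halogen on the benzyl group with the (1,3-thiazol-2-yl)sulfamoyl group held constant: chloro in place of fluoro gives a 1.3-fold higher number from compound 1 to compound 4 (0.11 log units; within the scatter), again within the scatter. No measurement is available that could explain any of these steps.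

At the aromatic carbon, the compounds shown carry only acetamido, sulfamoyl and (1,3-thiazol-2-yl)sulfamoyl, so it remains open whether a carboxylic acid or an amine there would also stay within the scatter, and the sulfonamide nitrogen has been read only with hydrogen and 1,3-thiazol-2-yl, leaving a methyl group or a phenyl ring open. Every benzyl group shown carries two halogens, so a benzyl group without halogen also remains open.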